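The compounds below may be only part of what the source reports. "The series", "measured", "known", "first", "only" and "open" are said of these compounds alone.

Working notes on the series, read in a functional assay on MIA PaCa-2 cells (Homo sapiens) for cytotoxicity, read by MTT assay, with a stated time of 4 h; on this read-out higher numbers stand for weaker inhibition and lower numbers for stronger inhibition. Compound 1 `COC1=CC(=O)c2c(COc3ccc(N)cc3)c(C)n(C)c2C1=O` gives 504 nM, compound 2 `COC1=CC(=O)c2c(COc3ccccn3)c(C)n(C)c2C1=O` gives 9580 nM, and compound 3 `COC1=CC(=O)c2c(COc3cccnc3)c(C)n(C)c2C1=O` gives 2480 nM, the second highest of the three numbers. Compound 4 `COC1=CC(=O)c2c(COc3ccncc3)c(C)n(C)c2C1=O` is not yet measured. Its change is pyridin-4-yl in place of pyridin-3-yl on an oxygen on a saturated carbon. Going by the values given here, the closest precedent is the modest step of a 3.9-fold lower number from compound 2 to compound 3 (0.59 log units; beyond the scatter), which also swaps one pyridinyl for another. The steps of a 19-fold higher number from compound 1 to compound 2 (1.28 log units; beyond the scatter) and a 4.9-fold higher number from compound 1 to compound 3 (0.69 log units; beyond the scatter) replace 4-aminophenyl and bear on it less directly. The data fix no direction, so the central expectation is no step beyond the scatter, though a modest step remains possible. The expected step is a 1.2-fold lower number from compound 3 to compound 4 (0.09 log units; within the scatter). For compound 4 the estimate is 2000 nM, with an expected range of 700 nM to 6000 nM.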

Compound 4, half-maximal inhibitory concentration: 2560 nM
For compound 4 the middle estimate is 1.3-fold (0.11 log units) below the measured one; the range from low to high includes it.
By their numbers in this assay, from the lowest: compound 1; then compounds 3 and 4 (each within the scatter of the next); then compound 2.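

In this assay, pyridin-4-yl and pyridin-3-yl on this oxygen cannot be told apart, with a 1.0-fold higher number from compound 3 to compound 4 (0.01 log units; within the scatter) in the series. The gap from pyridin-2-yl is therefore not unique to pyridin-3-yl, since a 3.7-fold lower number from compound 2 to compound 4 (0.57 log units; beyond the scatter) is of similar size to the earlier step. Pyridin-4-yl also does not close the gap to 4-aminophenyl, with a 5.1-fold higher number from compound 1 to compound 4 (0.71 log units; beyond the scatter) on this read-out.

Nothing available accounts for these differences. As far as these compounds go, whether the amine or the ring of 4-aminophenyl carries the difference stays open, and a plain phenyl or 4-hydroxyphenyl on the same oxygen would separate the two.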